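Swapping a hydroxy for a nitro on a weak cytotoxic scaffold

A few compounds are considered here, and "the series" means these few. Any claim that something is new, unique, unknown or untested is made for them only; others in the source may bear on it.

Measured compounds:
- compound 1, `COc1ccc(/C=C/C[C@@H]2C[C@@H]([C@@H](O)c3ccc(OC)c(OC)c3)CO[C@H]2c2ccc(OC)c(OC)c2)cc1`: 17100 nM
- compound 2, `Oc1ccccc1/C=C/C[C@H]1C[C@@H]([C@@H](O)c2ccccc2)CO[C@@H]1c1ccccc1`: 21800 nM
- compound 3, `COc1ccc([C@H]2OC[C@H]([C@@H](O)c3ccc(OC)c(OC)c3)C[C@@H]2C/C=C/c2ccccc2)cc1OC`: 14800 nM

All three compounds share a core that was tested in a functional assay on HeLa cells (Homo sapiens) for cytotoxicity, read by WST assay, with a stated time of 48 h; a lower number here means a stronger inhibitor, a higher number a weaker inhibitor. In this assay compound 1 gives 17100 nM, compound 3 gives 14800 nM, and compound 2 gives 21800 nM. Among the compounds with values here, these three numbers sit close together: the distance from compound 2 to compound 1 and to compound 3 stays inside the usual scatter of repeated measurements, so no compound can be called stronger or weaker than another on this evidence. All three are weak inhibitors in this assay.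

The unmeasured compound 4, `O=[N+]([O-])c1ccccc1/C=C/C[C@H]1C[C@@H]([C@@H](O)c2ccccc2)CO[C@@H]1c1ccccc1`, is compound 2 with one change: nitro in place of hydroxy on an aromatic carbon. Within the data shown here, no pair of measured compounds differs by this kind of exchange, so there is no measured step to lean on. With the three measured values so similar and the core unchanged, the expectation for compound 4 is a number close to that of compound 2, with no step beyond the scatter, though a modest shift in either direction cannot be ruled out.

Compound 4 is therefore expected to give about 20000 nM in this assay, within a range of 7000 nM to 60000 nM. The step this estimate implies is a 1.1-fold lower number from compound 2 to compound 4 (0.04 log units; within the scatter), which is expected to lie within the scatter.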

Compound 4, half-maximal inhibitory concentration: 11800 nM
For compound 4 the middle estimate is 1.7-fold (0.23 log units) above the measured one; measured number inside the range.
By their numbers in this assay, from the lowest: compounds 4, 3, 1 and 2 (each within the scatter of the next).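

In this assay the move from 2-hydroxyphenyl to 2-nitrophenyl gives a 1.8-fold lower number from compound 2 to compound 4 (0.27 log units; within the scatter) and so cannot be told apart from repeat measurements. Within the data shown here, this is the first sign that this aromatic carbon, ortho to a large group, can carry a hydrogen-bond donor in hydroxy or none in nitro, and a group of one heavy atom or of three, without a step beyond the scatter. Nothing measured here explains this result or links it to any property of either group.

On these data alone, whether an amine, a carboxylic acid or a single fluorine atom on this same carbon would also stay within the scatter remains open. So does whether any change at this carbon could move this weak series beyond the scatter at all.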